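A few compounds are considered here, and "the series" means these few. Any claim that something is new, unique, unknown or untested is made for them only; others in the source may bear on it.

Working notes on the series.

Compound 1 `Clc1cccc(-c2c[nH]c3ncnc(NCC4CC4)c23)c1` gives 213 nM in an assay for inhibition of serine/threonine-protein kinase 3 (Homo sapiens), read by luminescence and ADP-Glo, in the presence of a further agent that is not named here; a lower number here means a stronger inhibitor, a higher number a weaker inhibitor. Compound 2 `CNC1CCN(c2ncnc3[nH]cc(-c4cccc(Cl)c4)c23)CC1` gives 293 nM in this assay. Going by the values given here, the one step measured so far is a 1.4-fold higher number from compound 1 to compound 2 (0.14 log units; within the scatter). Among the compounds with values here, compound 2 thus holds the higher of the two numbers, with compound 1 as its only neighbour, and the gap between them lies within the scatter, so no order between the two is claimed.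

Compound 3 `CC1(O)CCN(c2ncnc3[nH]cc(-c4cccc(Cl)c4)c23)CC1` is not yet measured. Its difference from compound 2 is 4-hydroxy-4-methylpiperidin-1-yl in place of 4-(methylamino)piperidin-1-yl on an aromatic carbon. The only measured step, the one from compound 1 to compound 2, changed the group at the same place and left the number essentially unchanged, as shown by a 1.4-fold higher number from compound 1 to compound 2 (0.14 log units; within the scatter). Within the data shown here, no measured step speaks to a swap of the substituent on the piperidine ring itself, so the expectation for compound 3 rests on the absence of movement seen so far.

The step from compound 2 to compound 3 is expected to be a 1.0-fold higher number from compound 2 to compound 3 (0.01 log units; within the scatter), that is, nothing beyond the scatter. For compound 3 the value in this assay is estimated at 300 nM, with an expected range from 120 nM to 750 nM.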

Compound 3, half-maximal inhibitory concentration: 189 nM
Compound 3: the middle estimate sits 1.6-fold (0.20 log units) above what was measured, and the stated range covers the measured number.
By their numbers in this assay, from the lowest: compounds 3, 1 and 2 (each within the scatter of the next).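

Within this assay, the exchange of 4-(methylamino)piperidin-1-yl for 4-hydroxy-4-methylpiperidin-1-yl on the aromatic carbon next to the ring nitrogen gives a 1.6-fold lower number from compound 2 to compound 3 (0.19 log units; within the scatter), so this first measured change on the piperidine ring itself, which replaces a nitrogen with an oxygen in the group while the counts of heavy atoms, donors and acceptors stay the same, does not separate the two compounds. The comparison with the open-chain group gives a 1.1-fold lower number from compound 1 to compound 3 (0.05 log units; within the scatter), so all three groups at this place now lie within the scatter of one another, and this holds for the three listed compounds only. No supporting measurement bears on why the number stays within the scatter across these groups.

As far as these compounds go, whether a carboxylic acid or a longer alkyl chain at the 4-position of the piperidine, or a primary amine in place of the methylamino group, would move the number beyond the scatter remains open. From the compounds shown here alone, all three compounds share the same core, so it also remains open whether this insensitivity to the group would persist on a different core.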